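This account rests on a few compounds, and the source may have more. Where it says the series, first, only, none or still open, it means among the compounds named here.

Of the compounds shown here, two of this set have been measured in a functional assay on DLD-1 cells (Homo sapiens) for antiproliferative activity, read by CellTiter-Glo, with a stated time of 72 h; a higher number here means a weaker inhibitor, a lower number a stronger inhibitor. Compound 1 `COc1ccc(-c2cccc(S(=O)(=O)N3CCC(N4CCC(C)CC4)CC3)c2)cc1` gives 23 nM, the lowest of the two numbers. Compound 2 `CC1CCN(C2CCN(S(=O)(=O)c3ccc(-c4ccc(Cl)cc4)cc3)CC2)CC1` gives 105 nM, a higher number that lies beyond the usual scatter of this assay, so compound 1 is the stronger inhibitor of the pair.

The next compound, compound 3 `COc1cccc(S(=O)(=O)N2CCC(N3CCC(C)CC3)CC2)c1`, is derived from compound 1 by one change: methoxy in place of 4-methoxyphenyl on an aromatic carbon. The 4-methoxyphenyl that leaves carries a six-membered aromatic ring of carbon only, and the methoxy that enters has no ring, so compound 3 is a noticeably smaller molecule than compound 1, with the change placed meta to a large group on the shared core.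

Within the data shown here, no measured pair in this set tracks such a change, so the expectation rests on the shape of the two structures alone. Losing a whole aromatic ring is expected to weaken the inhibitor clearly, by a step of a 17-fold higher number from compound 1 to compound 3 (1.24 log units; beyond the scatter), which would be well beyond the scatter. Compound 3 is therefore estimated at 400 nM, somewhere between 80 nM and 2500 nM.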

Compound 3, half-maximal inhibitory concentration: > 5000 nM
Compound 3: no number, only a limit (the forecaster's own chance of this, stated with the estimate: 10%); middle value at least 12-fold (1.09 log units) away from the limit.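

Among these compounds, replacing 4-methoxyphenyl with methoxy on this aromatic carbon, meta to a large group, gives an at least 210-fold higher number from compound 1 to compound 3 (2.33 log units; beyond the scatter) in this assay, the first step in the set that changes only one place, and it shows that the group at this position weighs heavily on the result. Compound 3 has no exact number, and its value is only a limit of the assay: the limit of > 5000 nM in this assay, at which 1 of the 3 values shown sits. The two groups have the same counts of hydrogen-bond donors and acceptors and neither carries a net charge, so the difference between them in these counts lies in the six-membered aromatic ring of carbon only and in the number of heavy atoms.

The compounds shown leave open whether an aromatic ring is needed at this position or whether a non-aromatic group of similar size, such as cyclohexyl, or a longer chain, such as butoxy, could take its place. They also leave open what the methoxy on the ring contributes, a question that a plain phenyl group at the same position would address.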